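Piperidin-1-yl for Diethylamino on the Tert-Butyl Core

This account rests on a few compounds, and the source may have more. Where it says the series, first, only, none or still open, it means among the compounds named here.

Compound 1 `CCN(CC)CCNc1n[n+]([O-])c2ccc(C)cc2[n+]1[O-]` and compound 2 `Cc1ccc2c(c1)[n+]([O-])c(NCCN1CCCCC1)n[n+]2[O-]` share one core and differ in a single place: piperidin-1-yl in place of diethylamino on a saturated chain carbon, two bonds along the chain from a nitrogen on an aromatic ring. In a physicochemical assay for solubility, in the presence of a further agent that is not named here (on this read-out higher numbers stand for higher solubility and lower numbers for lower solubility), compound 1 gives > 49000000 nM, which is a limit of the assay rather than a number. In this assay compound 2 gives 45000000 nM. The step is an at least 1.0-fold lower number from compound 1 to compound 2 (0.03 log units; that floor lies within the scatter), so the change to piperidin-1-yl left solubility essentially where it stood. Compound 3 `CCN(CC)CCNc1n[n+]([O-])c2ccc(C(C)(C)C)cc2[n+]1[O-]` differs from compound 1 in the core: tert-butyl in place of methyl on an aromatic carbon. In this assay compound 3 gives > 48000000 nM, again a limit of the assay. The step that the two limits leave unreadable from compound 1 to compound 3 cannot be sized, since both ends sit at limits, as the limit of > 48000000 nM in this assay, at which 1 of the 3 values shown sits, and the limit of > 49000000 nM in this assay, at which 1 of the 3 values shown sits, show.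

Compound 4 `CC(C)(C)c1ccc2c(c1)[n+]([O-])c(NCCN1CCCCC1)n[n+]2[O-]` has not yet been measured. It differs from compound 3 by piperidin-1-yl in place of diethylamino on a saturated chain carbon, two bonds along the chain from a nitrogen on an aromatic ring, the same kind of change that separates compound 1 from compound 2, at a place described in the same words. On the tert-butyl core the outcome is expected to be an at least 1.0-fold lower number from compound 3 to compound 4 (0.02 log units; that floor lies within the scatter), resting on compound 1 and compound 2 and their step of an at least 1.0-fold lower number from compound 1 to compound 2 (0.03 log units; that floor lies within the scatter), which stayed within the scatter. Compound 4 is therefore expected to give about 45000000 nM in this assay, with a range from 20000000 nM to 60000000 nM.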

Compound 4, solubility: 28000000 nM
The estimate for compound 4 lay 1.6-fold (0.21 log units) above the measured number; the range from low to high includes it.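

In this assay, piperidin-1-yl in place of diethylamino on the core of compound 3 gives an at least 1.7-fold lower number from compound 3 to compound 4 (0.23 log units; that floor lies within the scatter), and the same change on the core of compound 1 gives an at least 1.0-fold lower number from compound 1 to compound 2 (0.03 log units; that floor lies within the scatter), so on both cores the smallest size the data allow for the step stays within the scatter. The two piperidin-1-yl compounds are linked by a 1.6-fold lower number from compound 2 to compound 4 (0.21 log units; within the scatter), which fits the change carrying from one core to the other without a readable departure, though only these two cores stand behind that reading. The true size of the step on the core of compound 3 stays unfixed, and so does any match with the step on the core of compound 1, which also starts from a limit, because compound 3 gives only a limit of the assay: the limit of > 48000000 nM in this assay, at which 1 of the 4 values shown sits.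

The compounds shown leave open whether the same reading would hold for another cyclic amine, such as morpholin-4-yl or pyrrolidin-1-yl, or for a longer chain between the aromatic ring nitrogen and the amine. They also leave open how the change would behave on a core carrying a group other than methyl or tert-butyl, such as chloro or methoxy, at that aromatic carbon.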